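The source may hold more compounds than are shown below. What is called first, only, known or untested is meant among the compounds shown, and "the series" means these compounds.

In an ADME assay on SH-SY5Y cells (Homo sapiens) for cytotoxicity, read by MTT assay, with a stated time of 72 h (a lower number here means a stronger inhibitor, a higher number a weaker inhibitor), compound 1 `COc1ccc2[nH]cc(CCCN3CCN(C(=O)CN4CCN(C(=O)c5ccccc5)CC4)CC3)c2c1` gives > 200000 nM, which is a limit of the assay and not a number. Compound 2 `COc1ccc2[nH]cc(CCCN3CCN(C(=O)CN4CCN(C(=O)c5ccc(F)cc5)CC4)CC3)c2c1` gives > 200000 nM, also only a limit. The evidence so far is the limit of > 200000 nM in this assay, at which 2 of the 2 values shown sit. Compound 3 `COc1ccc2[nH]cc(CCCN3CCN(C(=O)CN4CCN(C(=O)c5ccccc5Br)CC4)CC3)c2c1` differs from compound 2 by 2-bromophenyl in place of 4-fluorophenyl on a carbonyl carbon. Among the measured compounds shown here, the one measured step, a step that the two limits leave unreadable from compound 1 to compound 2, offers no size to carry over, so no change beyond the scatter is expected in this assay, in either direction. The estimated step is a number no higher from compound 2 to compound 3 (the limit leaves the size open). Compound 3 is expected at 200000 nM, with an estimated range of 80000 nM to 400000 nM.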

Compound 3, half-maximal inhibitory concentration: 111000 nM
For compound 3 the middle estimate is 1.8-fold (0.26 log units) above the measured one, and the stated range covers the measured number.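

Among the compounds shown here, compound 3 is the first here to give a measured number rather than a limit in this assay, so a change on this phenyl ring attached to the carbonyl can bring cell toxicity into readable range. Replacing 4-fluorophenyl with 2-bromophenyl gives an at least 1.8-fold lower number from compound 2 to compound 3 (0.25 log units; that floor lies within the scatter), and adding a bromo group to the phenyl ring gives an at least 1.8-fold lower number from compound 1 to compound 3 (0.25 log units; that floor lies within the scatter). As far as these compounds go, both are only floors, so the true size of each step remains unknown.

The compounds shown leave open how an amine or a carboxylic acid in place of the bromo would read.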